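The source may report more compounds than this note shows. Statements on the series, on what has been measured and on what is new or still open speak of the compounds shown alone.

Measured so far:
compound 1, `O=C(COc1cccc2ccccc12)N/N=C/c1ccc([N+](=O)[O-])cc1` — 14.2 ug/mL
compound 2, `CSc1ccc(/C=N/NC(=O)COc2cccc3ccccc23)cc1` — > 100 ug/mL

In an ADME assay on HEL cells (Homo sapiens) for cytotoxicity (a lower number here means that less compound is tolerated, a higher number that more compound is tolerated), compound 1 gives 14.2 ug/mL. Compound 2 reaches only the limit of this assay, > 100 ug/mL, so for compound 2 a bound and no number is known. Compound 2 sits at the limit of > 100 ug/mL in this assay, at which 1 of the 2 values shown sits. Among the measured compounds shown here, the one measured step, an at least 7.0-fold higher number from compound 1 to compound 2 (0.84 log units; beyond the scatter), carries the number past that bound.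

Compound 3, `O=C(COc1cccc2ccccc12)N/N=C/c1ccc(F)cc1`, differs from compound 2 by fluoro in place of methylsulfanyl on an aromatic carbon. For the measured compounds named here, no measured step covers this particular change; the step from compound 1 to compound 2 shows only that the group on this aromatic carbon can shift the number strongly. Fluoro is neither the nitro of compound 1 nor the methylsulfanyl of compound 2, so a number between the two is expected. The estimate for compound 3 is 50 ug/mL, with a range of 20 ug/mL to 100 ug/mL, meaning an expected step of an at least 2.0-fold lower number from compound 2 to compound 3 (0.30 log units; that floor lies within the scatter), and a real chance that only the limit is reported again.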

Compound 3, half-maximal cytotoxic concentration: 71.6 ug/mL
Beside the measured number, compound 3's estimate is 1.4-fold (0.16 log units) below it; low and high end bracket the measured number.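

Working from this assay, fluoro on this aromatic carbon gives a 5.0-fold higher number from compound 1 to compound 3 (0.70 log units; beyond the scatter), so a higher number than that of the nitro compound does not depend on methylsulfanyl. Both replacements of nitro shown, fluoro and methylsulfanyl, raise the number beyond the scatter, which leaves compound 1 as the low member of these three compounds. Fluoro against methylsulfanyl gives an at least 1.3-fold lower number from compound 2 to compound 3 (0.14 log units; that floor lies within the scatter), and the full size of this change stays unknown, the methylsulfanyl value being a limit of the assay and not a number: the limit of > 100 ug/mL in this assay, at which 1 of the 3 values shown sits.

As far as these compounds go, whether the number on this aromatic carbon follows any order beyond these three groups stays open; an amine, a carboxylic acid or a longer chain there would test it. From the compounds shown here alone, how far fluoro truly lies from methylsulfanyl in this assay also stays open.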